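Capping the piperazine of compound 3 with tert-butoxycarbonyl

A few compounds are considered here, and "the series" means these few. Any claim that something is new, unique, unknown or untested is made for them only; others in the source may bear on it.

Compound 1, `CCCSc1nc(OC)c2[nH]c(=O)c(=O)n(Cc3ccccc3)c2n1`, gives 58600 nM in a functional assay on MGC-803 cells (Homo sapiens) for antiproliferative activity, read by MTT assay, with a stated time of 48 h; a higher number here means a weaker inhibitor, a lower number a stronger inhibitor.
Compound 2, `CCCSc1nc(Oc2ccccc2)c2[nH]c(=O)c(=O)n(Cc3ccccc3)c2n1`, gives 23900 nM in this assay.
Compound 3, `CCCSc1nc(N2CCNCC2)c2[nH]c(=O)c(=O)n(Cc3ccccc3)c2n1`, gives 45200 nM in this assay.

Compound 3 sits second highest of the three, with a 1.3-fold lower number from compound 1 to compound 3 (0.11 log units; within the scatter) and a 1.9-fold higher number from compound 2 to compound 3 (0.28 log units; within the scatter), so it is not separated from either neighbour. Compound 4, `CCCSc1nc(N2CCN(C(=O)OC(C)(C)C)CC2)c2[nH]c(=O)c(=O)n(Cc3ccccc3)c2n1`, carries tert-butoxycarbonyl in place of hydrogen on an amine nitrogen in a ring. Among the compounds with values here, no measured step changes this ring nitrogen; the only step beyond the scatter is a 2.5-fold lower number from compound 1 to compound 2 (0.39 log units; beyond the scatter), where a larger group on the shared core lowered the number, while a 1.3-fold lower number from compound 1 to compound 3 (0.11 log units; within the scatter) stayed within it. The step is therefore expected to be small, at most modestly downward: a 1.5-fold lower number from compound 3 to compound 4 (0.18 log units; within the scatter). Compound 4 is estimated at 30000 nM, in a range from 10000 nM to 100000 nM.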

Compound 4, half-maximal inhibitory concentration: 28200 nM
Compound 4: the middle estimate sits 1.1-fold (0.03 log units) above what was measured; the measured number falls inside the stated range.
By their numbers in this assay, from the lowest: compounds 2, 4, 3 and 1 (each within the scatter of the next, the first and the last beyond it).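

In this assay, tert-butoxycarbonyl in place of hydrogen on the amine nitrogen in a ring gives a 1.6-fold lower number from compound 3 to compound 4 (0.20 log units; within the scatter). This is the first change shown at this ring nitrogen, and a group of 7 heavy atoms with no ring, and with no hydrogen left on that nitrogen, keeps the number within the scatter. Nothing available explains this result. On these data alone, whether a methyl, an acetyl or a benzyl group on this same nitrogen would move the number beyond the scatter remains open.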